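A few compounds are considered here, and "the series" means these few. Any claim that something is new, unique, unknown or untested is made for them only; others in the source may bear on it.

Measured in an ADME assay (liver) for metabolic stability, with Liver microsome (Homo sapiens) as the target, using microsomes and NADPH, with a stated time of 30 min, tested at 1 uM; on this read-out lower numbers stand for slow clearance and higher numbers for fast clearance:
Compound 1 `Nc1ccc(S(=O)(=O)N2CCN(c3ncc(C(O)(C(F)(F)F)C(F)(F)F)cc3-c3cccnc3)CC2)cn1`: 17 mL.min-1.g-1
Compound 2 `Cc1ccc(-c2cc(C(O)(C(F)(F)F)C(F)(F)F)cnc2N2CCN(S(=O)(=O)c3ccc(N)nc3)CC2)cn1`: 43 mL.min-1.g-1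
Compound 3 `Cc1nc2cc(-c3cc(C(O)(C(F)(F)F)C(F)(F)F)cnc3N3CCN(S(=O)(=O)c4ccc(N)nc4)CC3)ccc2o1`: < 14 mL.min-1.g-1 (a limit)

Compound 3 stands at < 14 mL.min-1.g-1, which is a limit of the assay and not a number (the limit of < 14 mL.min-1.g-1 in this assay, at which 1 of the 3 values shown sits).

Compound 4 `Nc1ccc(S(=O)(=O)N2CCN(c3ncc(C(O)(C(F)(F)F)C(F)(F)F)cc3-c3cccc4[nH]ncc34)CC2)cn1` carries 1H-indazol-4-yl in place of 2-methyl-1,3-benzoxazol-5-yl (1H-indazol-4-yl in place of 2-methyl-1,3-benzoxazol-5-yl on an aromatic carbon). Both groups hold one five-membered aromatic ring with 2 hetero atoms and one six-membered aromatic ring of carbon only.

Two measured steps change the group at this place: an at least 1.2-fold lower number from compound 1 to compound 3 (0.08 log units; that floor lies within the scatter) and an at least 3.0-fold lower number from compound 2 to compound 3 (0.48 log units; beyond the scatter). Both rest on the limit, and neither brings in 1H-indazol-4-yl. The methyl step, a 2.5-fold higher number from compound 1 to compound 2 (0.40 log units; beyond the scatter), is modest.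

A small step is expected in this assay, upward if a number is reported at all, as compound 1 reaches 17 mL.min-1.g-1 in the same series. The expected move is an at least 1.0-fold higher number from compound 3 to compound 4 (0.02 log units; that floor lies within the scatter). Compound 4 is estimated at 15 mL.min-1.g-1, with an expected range of 8 mL.min-1.g-1 to 35 mL.min-1.g-1.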

Compound 4, intrinsic clearance in microsomes: 42 mL.min-1.g-1
For compound 4 the middle estimate is 2.8-fold (0.45 log units) below the measured one, and the stated range ends below it.
By their numbers in this assay, from the lowest: compound 1; then compounds 4 and 2 (each within the scatter of the next). At a limit, below all of these: compound 3.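

In this assay, 1H-indazol-4-yl and 2-methyl-1,3-benzoxazol-5-yl hold the same ring types at this aromatic carbon, yet the exchange gives an at least 3.0-fold higher number from compound 3 to compound 4 (0.47 log units; beyond the scatter), so the ring types alone do not set the read-out here. Compound 3 stands at a limit and not a number, so this step is only a floor: the limit of < 14 mL.min-1.g-1 in this assay, at which 1 of the 4 values shown sits. Replacing pyridin-3-yl with 1H-indazol-4-yl gives a 2.5-fold higher number from compound 1 to compound 4 (0.39 log units; beyond the scatter), while replacing 6-methylpyridin-3-yl with it gives a 1.0-fold lower number from compound 2 to compound 4 (0.01 log units; within the scatter), so these last two groups cannot be told apart in this read-out.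

Still open, as far as these compounds go, is whether the step follows the hetero atoms of the five-membered ring, the methyl or the point of attachment. A 1-methyl-1H-indazol-4-yl or a 1,3-benzoxazol-5-yl group at this position would help separate these.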